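This account rests on a few compounds, and the source may have more. Where it says the series, first, only, none or still open, it means among the compounds named here.

Compound 1 `CCn1c(C(=O)NCCN(C)C)ccc1C(CC)(CC)c1ccc(OCC(=O)C(C)(C)C)c(C)c1`: 77 nM in an assay on HL-60 cells for agonist activity at vitamin D3 receptor (Homo sapiens), read by microscopy, with a stated time of 96 h; a lower number here means that less compound is needed, a higher number that more compound is needed for the effect
Compound 2 `CCN(CC)CCCNC(=O)c1ccc(C(CC)(CC)c2ccc(OCC(=O)C(C)(C)C)c(C)c2)n1CC`: 22 nM in this assay

Among the compounds with values here, of the two compounds measured so far, compound 2 gives the lowest number, its nearest neighbour being compound 1 with 77 nM. Within the data shown here, the single step between them, a 3.5-fold lower number from compound 1 to compound 2 (0.54 log units; beyond the scatter), changes only the basic amine end of the side chain on the amide-type nitrogen. Compound 3 `CCn1c(C(=O)NCC(OC)OC)ccc1C(CC)(CC)c1ccc(OCC(=O)C(C)(C)C)c(C)c1` is not yet measured. It differs from compound 2 by dimethoxymethyl in place of 2-(diethylamino)ethyl on a saturated chain carbon bound to an amide-type nitrogen. Among the measured compounds shown here, the measured step bears on it only indirectly: it shows that the amine end of this chain shifts the number modestly, but no measured compound lacks a basic amine there altogether. Since compound 2 already stands lowest, the expected step for compound 3 is a 2.7-fold higher number from compound 2 to compound 3 (0.44 log units; beyond the scatter), toward a higher number. Compound 3 is therefore estimated at 60 nM, within a range from 20 nM to 200 nM.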

Compound 3, half-maximal effective concentration: 130 nM
For compound 3 the middle estimate is 2.2-fold (0.34 log units) below the measured one, and the stated range covers the measured number.
By their numbers in this assay, from the lowest: compound 2; then compounds 1 and 3 (each within the scatter of the next).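

In this assay, the amine at the end of the chain proves not to be needed for a measurable effect: the dimethoxymethyl end, which carries no nitrogen, gives a number within the scatter of the shorter dimethylamino end (a 1.7-fold higher number from compound 1 to compound 3 (0.23 log units; within the scatter)). The advantage of the amine shows only against the 2-(diethylamino)ethyl group, and there the replacement gives a clear step (a 5.9-fold higher number from compound 2 to compound 3 (0.77 log units; beyond the scatter)), larger than the one between the two amine ends. No measurement given here explains either step.

The compounds shown leave open whether a carboxylic acid or a hydroxyl at the chain end would behave like dimethoxymethyl. They also leave open whether a dipropylamino end or a longer chain carrying the diethylamino group would lower the number further.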